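Chain length between the furan core and the acid

The source may report more compounds than this note shows. Statements on the series, on what has been measured and on what is new or still open speak of the compounds shown alone.

Compound 1 `Cc1oc(CCC(=O)O)cc1COc1ccc(-c2ccccc2)cc1` and compound 2 `Cc1oc(C(=O)O)cc1COc1ccc(-c2ccccc2)cc1` share the same core and differ only in the acid-bearing chain. In an assay on cells for displacement of a labelled ligand from prostaglandin E2 receptor EP4 subtype (Homo sapiens), read by scintillation counting (on this read-out lower numbers stand for stronger inhibition and higher numbers for weaker inhibition), compound 1 gives 80 nM, and compound 2 gives 420 nM. Among the compounds with values here, the single measured step, a 5.3-fold higher number from compound 1 to compound 2 (0.72 log units; beyond the scatter), puts compound 2 at the highest of the two numbers, with compound 1 as its only neighbour and the gap lying beyond the scatter.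

Compound 3 `Cc1oc(CC(=O)O)cc1COc1ccc(-c2ccccc2)cc1` is the next member: carboxymethyl in place of carboxy on an aromatic carbon. This change reinserts one chain carbon of the two that were lost between compound 1 and compound 2, so the step that bears on it is a 5.3-fold higher number from compound 1 to compound 2 (0.72 log units; beyond the scatter), read in reverse and only partway. A drop in this assay toward the number of compound 1 is therefore expected, of a size smaller than the full step but plausibly beyond the scatter, with no basis for expecting it to pass below compound 1.

The step from compound 2 to compound 3 is estimated as a 2.3-fold lower number from compound 2 to compound 3 (0.37 log units; beyond the scatter). Compound 3 is estimated at 180 nM, with a range of 70 nM to 450 nM.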

Compound 3, inhibition constant: 80 nM
For compound 3 the middle estimate is 2.3-fold (0.35 log units) above the measured one; the range from low to high includes it.
By their numbers in this assay, from the lowest: compounds 1 and 3 (each within the scatter of the next); then compound 2.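

Working notes on the acid-bearing chain: the earlier step could not show whether the change in the number followed chain length gradually or came from a single carbon. In this assay, carboxymethyl in place of carboxy on the aromatic carbon next to the ring oxygen gives a 5.3-fold lower number from compound 2 to compound 3 (0.72 log units; beyond the scatter), which matches in size the full step between compound 1 and compound 2, so across these three compounds the whole gap lies between carboxy and carboxymethyl. The further carbon of the 2-carboxyethyl chain gives no change at the digits printed from compound 1 to compound 3 (within the scatter), so at this position compound 1 and compound 3 cannot be told apart, and only compound 2, with its acid attached directly to the aromatic carbon, stands apart from them, while nothing at hand bears on why this single carbon accounts for the gap.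

From the compounds shown here alone, whether the flat read-out across carboxymethyl and 2-carboxyethyl extends to a longer chain such as 3-carboxypropyl remains open. Also open, going by these compounds, is whether the chain tolerates a methyl branch on its saturated carbon, or whether a tetrazole or a primary amide can stand in for the carboxylic acid at the end of the chain.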